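A Methyl on the Ring: Little Change Expected

The source may report more compounds than this note shows. Statements on the series, on what has been measured and on what is new or still open speak of the compounds shown alone.

Two thiol-bearing amides share one core and differ only in the acid-bearing chain on the ring nitrogen. Compound 1 `O=C(O)CN1C(=O)[C@@H](NC(=O)[C@@H](S)Cc2ccccc2)COc2ccccc21` carries a carboxymethyl group; in an assay on isolated protein for inhibition of Neprilysin (Homo sapiens) (a lower number here means a stronger inhibitor, a higher number a weaker inhibitor), compound 1 gives 3.1 nM. Compound 2 `O=C(O)CCN1C(=O)[C@@H](NC(=O)[C@@H](S)Cc2ccccc2)COc2ccccc21` lengthens this chain to a 2-carboxyethyl group, and in this assay compound 2 gives 1.2 nM. The step of a 2.6-fold lower number from compound 1 to compound 2 (0.41 log units; beyond the scatter) is the only measured one so far, and it leaves compound 2 with the lowest of the two numbers.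

Compound 3 `C[C@H]1Oc2ccccc2N(CCC(=O)O)C(=O)[C@H]1NC(=O)[C@@H](S)Cc1ccccc1` keeps the chain of compound 2 and differs from it by methyl in place of hydrogen on a saturated ring carbon, a methyl in place of hydrogen on a saturated ring carbon of the seven-membered non-aromatic ring. Among the compounds with values here, no measured step touches this part of the core: the one known step concerns the chain on the nitrogen and says nothing about a small group on the ring. With nothing to point either way, the expectation is a step within the scatter. Compound 3 is therefore estimated at 1.5 nM in this assay, with a range from 0.5 nM to 5 nM. The expected step is a 1.3-fold higher number from compound 2 to compound 3 (0.10 log units; within the scatter).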

Compound 3, half-maximal inhibitory concentration: 83 nM
The estimate for compound 3 lay 55-fold (1.74 log units) below the measured number; the whole stated range lies below it.
By their numbers in this assay, from the lowest: compound 2; then compound 1; then compound 3.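

This ring carbon, next to the ring oxygen and next to the ring atom that bears a large group, is far from a silent place on the shared core. In this assay, methyl in place of hydrogen gives a 69-fold higher number from compound 2 to compound 3 (1.84 log units; beyond the scatter), a large step from a change of only 1 heavy atom, and it far outweighs the modest 2.6-fold lower number from compound 1 to compound 2 (0.41 log units; beyond the scatter) seen on the chain at the ring nitrogen. So the earlier picture of a core that could take a small addition without consequence does not hold here, although nothing measured on these compounds explains the loss of strength.

The compounds shown leave open whether the effect belongs to methyl alone or would also appear with a fluorine, a hydroxyl or an ethyl on the same ring carbon, and whether the methyl arranged the opposite way in space would behave the same. They also leave open whether this methyl would cost as much on the carboxymethyl chain of compound 1 as it does on the 2-carboxyethyl chain.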